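Changing the Urea Aryl Group: Compound 4 Awaited

A few compounds are considered here, and "the series" means these few. Any claim that something is new, unique, unknown or untested is made for them only; others in the source may bear on it.

Three compounds have been measured in a functional assay on HCC827 cells (Homo sapiens) for inhibition, read by MTT assay, with a stated time of 48 h, tested at 10 uM; on this read-out lower numbers stand for less inhibition and higher numbers for more inhibition at the one concentration tested (going by the name of the read-out):
compound 1 `COc1cc(NC(=O)Nc2cc(Nc3ccc(OC)c(C)c3)ncn2)cc(OC)c1` gives 48.3%
compound 2 `CCc1cccc(Nc2cc(NC(=O)Nc3cc(OC)cc(OC)c3)ncn2)c1` gives 52.6%
compound 3 `COc1cc(NC(=O)Nc2cc(Nc3cc(C)cc(F)c3)ncn2)cc(OC)c1` gives 62.1%

Compound 1 stands lowest of these three numbers. Its nearest neighbour is compound 2, with a number 4.3 percentage points higher from compound 1 to compound 2 (within the scatter); its furthest is compound 3, with a number 13.8 percentage points higher from compound 1 to compound 3 (beyond the scatter). Between the other two compounds the difference is a number 9.5 percentage points higher from compound 2 to compound 3 (within the scatter).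

Compound 4 `COc1ccc(Nc2cc(NC(=O)Nc3c(Cl)cccc3Cl)ncn2)cc1C` differs from compound 1 at a different place: 2,6-dichlorophenyl in place of 3,5-dimethoxyphenyl on an amide-type nitrogen. The new group sits on the amide-type nitrogen whose other neighbour is a carbonyl carbon, while every measured step changed the group on the aromatic nitrogen instead. Among the compounds with values here, no measured step therefore bears directly on this change. What the measured steps do show is that swapping the aryl group on the other nitrogen moved the read-out from within the scatter to a modest amount. With no direct guidance, compound 4 is expected to land near the measured compounds, with a step of a number 1.7 percentage points higher from compound 1 to compound 4 (within the scatter) that may well stay within the scatter, giving an estimate of 50% with a range from 28% to 72%.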

Compound 4, a percentage reported as inhibition, at one concentration (the size of the read-out at that concentration, not a potency): 63.1%
For compound 4 the middle estimate is 13.1 percentage points below the measured one; the range from low to high includes it.
By their numbers in this assay, from the lowest: compounds 1, 2, 3 and 4 (each within the scatter of the next, the first and the last beyond it).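

Within the data shown here, the position on the amide-type nitrogen, which no earlier step had touched, also responds in this assay: 2,6-dichlorophenyl in place of 3,5-dimethoxyphenyl gives a number 14.8 percentage points higher from compound 1 to compound 4 (beyond the scatter). The inhibition read-out therefore does not depend on keeping the 3,5-dimethoxyphenyl group here, and with an aryl group with no hydrogen-bond acceptors at this place on the core of compound 1 the number is higher. Nothing available explains why this exchange raises the number.

With a single replacement shown on this nitrogen, it remains open whether the step follows from the arrival of the two chlorine atoms or the departure of the two methoxy groups. An unsubstituted phenyl or a 2,6-dimethylphenyl group at the same place could help to separate these two readings.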